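Removing the carboxy group from compound 3

The source may report more compounds than this note shows. Statements on the series, on what has been measured and on what is new or still open speak of the compounds shown alone.

Compound 1 `COc1ccc(/C=C\c2cc(OC)c(OC)c(OC)c2)cc1OCc1ccc(CN2C[C@H](O)C[C@@H]2C(=O)O)cc1` and compound 2 `COc1ccc(/C=C\c2cc(OC)c(OC)c(OC)c2)cc1OCc1ccc(CN2CCCC[C@H]2C(=O)O)cc1` and compound 3 `COc1ccc(/C=C\c2cc(OC)c(OC)c(OC)c2)cc1OCc1ccc(CN[C@H](C(=O)O)[C@H](C)O)cc1` share one core and differ in the group on its saturated chain carbon. In a functional assay on MC-38 cells (Mus musculus) for antiproliferative activity, read by CCK-8 assay, with a stated time of 48 h (on this read-out lower numbers stand for stronger inhibition and higher numbers for weaker inhibition), compound 1 gives > 10000 nM as a limit and not a number. Compound 2 gives > 10000 nM as a limit too. Compound 3 also gives > 10000 nM as a limit, so it has no exact standing. Together they show the limit of > 10000 nM in this assay, at which 3 of the 3 values shown sit, with no number among them.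

The move to compound 4 `COc1ccc(/C=C\c2cc(OC)c(OC)c(OC)c2)cc1OCc1ccc(CNCCO)cc1` is 2-hydroxyethyl in place of 1-carboxy-2-hydroxypropyl on an amine nitrogen and puts 2-hydroxyethyl in place of 1-carboxy-2-hydroxypropyl on an amine nitrogen. Among the measured compounds shown here, three measured steps bear on it, namely a step that the two limits leave unreadable from compound 1 to compound 2 and a step that the two limits leave unreadable from compound 1 to compound 3 and a step that the two limits leave unreadable from compound 2 to compound 3 and none offers a size to carry over. All three measured compounds hold a carboxy group, and compound 4 has none. With compound 3 at > 10000 nM as a limit, a shift towards stronger inhibition in this assay is expected, though only roughly. The estimated change is an at least 10-fold lower number from compound 3 to compound 4 (1.00 log units; beyond the scatter) in size. Compound 4 is estimated at 1000 nM with an expected range from 50 nM to 10000 nM overall.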

Compound 4, half-maximal inhibitory concentration: 1200 nM
Compound 4: middle estimate off by 1.2-fold (0.08 log units), on the low side, and the stated range covers the measured number.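

In this assay, this place on the amine nitrogen now gives a readable result: putting 2-hydroxyethyl in place of 1-carboxy-2-hydroxypropyl gives an at least 8.3-fold lower number from compound 3 to compound 4 (0.92 log units; beyond the scatter). The same group also improves on 2-carboxypiperidin-1-yl, with an at least 8.3-fold lower number from compound 2 to compound 4 (0.92 log units; beyond the scatter), and on 2-carboxy-4-hydroxypyrrolidin-1-yl, with an at least 8.3-fold lower number from compound 1 to compound 4 (0.92 log units; beyond the scatter). Each size is only a minimum, because the other three compounds share one limit rather than having numbers: the limit of > 10000 nM in this assay, at which 3 of the 4 values shown sit.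

The change from compound 3 to compound 4 removes the carboxy group and also makes the group smaller, so the compounds shown cannot say which of these matters. A carboxymethyl group on the same nitrogen would help separate the two, while a longer chain such as 3-hydroxypropyl or an amine such as 2-aminoethyl would show how much room remains for change here.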